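The compounds below may be only part of what the source reports. "The series", "measured", "known", "first", "only" and "open" are said of these compounds alone.

Of the compounds shown here, two on a shared core have been measured so far. In a functional assay on A549 cells (Homo sapiens) for cytotoxicity, read by sulforhodamine B assay (on this read-out lower numbers stand for stronger inhibition and higher numbers for weaker inhibition), compound 1 `CN1CCN(c2nc(-c3ccc(Cl)cc3)cc3c(N(C)C)cccc23)CC1` gives 7450 nM and compound 2 `COc1ccc(-c2cc3c(N(C)C)cccc3c(N3CCN(C)CC3)n2)cc1` gives 1820 nM as the lower of the two numbers. Compound 3 `CN1CCN(c2nc(-c3ccccc3)cc3c(N(C)C)cccc23)CC1` is still unmeasured and differs from compound 2 by hydrogen in place of methoxy on an aromatic carbon as a single change, hydrogen in place of methoxy on an aromatic carbon. Among the compounds with values here, no compound carrying hydrogen there has been measured, so the only guide to size is a 4.1-fold lower number from compound 1 to compound 2 (0.61 log units; beyond the scatter) with methoxy in place of chloro on an aromatic carbon, a modest step beyond the scatter. On that guide a modest rise in the number is expected, of similar size or smaller. The estimated change is a 1.9-fold higher number from compound 2 to compound 3 (0.28 log units; within the scatter) in this assay terms. For compound 3 the expected value is 3500 nM within an estimated range of 1300 nM to 9000 nM on this read-out.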

Compound 3, half-maximal inhibitory concentration: 10000 nM
Beside the measured number, compound 3's estimate is 2.9-fold (0.46 log units) below it; the measured number lies above the stated range.
By their numbers in this assay, from the lowest: compound 2; then compounds 1 and 3 (each within the scatter of the next).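

In this assay the change from 4-methoxyphenyl to phenyl gives a 5.5-fold higher number from compound 2 to compound 3 (0.74 log units; beyond the scatter) and so shows that methoxy, para to a large group, separates compound 2 from the compound carrying hydrogen there. Hydrogen in place of chloro gives a 1.3-fold higher number from compound 1 to compound 3 (0.13 log units; within the scatter) and leaves compound 1 and compound 3 within the scatter of each other on this read-out. Among the three groups shown at this place, then, only methoxy stands apart, with chloro and hydrogen not told apart.

Nothing in the data shown accounts for this difference. From the compounds shown here alone, it remains open whether the step is particular to methoxy or would also be seen with a hydroxyl, an ethoxy or an amine at the same place, and whether it would hold on another core.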